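Swapping a Trifluoromethyl for a Methylpiperazine

A few compounds are considered here, and "the series" means these few. Any claim that something is new, unique, unknown or untested is made for them only; others in the source may bear on it.

Measured compounds:
- compound 1, `CC(C)(C)CC(C)(C)c1ccc(OCC(=O)Nc2ccc(C(F)(F)F)cc2)cc1`: 3440 nM
- compound 2, `COC(=O)c1cccc(NC(=O)COc2ccc(C)cc2)c1`: > 40000 nM
- compound 3, `CC(C)(C)CC(C)(C)c1ccc(OCC(=O)N2CCN(Cc3ccc(C(F)(F)F)cc3)CC2)cc1`: 4740 nM

In an assay for inhibition of malate dehydrogenase, cytoplasmic (Homo sapiens), with a stated time of 30 min (on this read-out higher numbers stand for weaker inhibition and lower numbers for stronger inhibition), compound 1 gives 3440 nM. Compound 3 gives 4740 nM in this assay, and the two numbers lie within the usual scatter of each other. Compound 2 reaches only (the limit of > 40000 nM in this assay, at which 1 of the 3 values shown sits), so for compound 2 a limit is reported rather than a number. Among the two measured numbers, compound 1 carries the lower one.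

The new structure is compound 4, `CN1CCN(c2ccc(NC(=O)COc3ccc(C(C)(C)CC(C)(C)C)cc3)cc2)CC1`. It differs from compound 1 in one place: 4-methylpiperazin-1-yl in place of trifluoromethyl on an aromatic carbon. Among the measured compounds shown here, no measured pair of compounds shows a change of this kind, so the size of the step can only be guessed. The expectation is a step from compound 1 to compound 4 of a 1.7-fold higher number from compound 1 to compound 4 (0.24 log units; within the scatter), with no clear direction beyond the scatter and a slight lean toward a higher number. On that basis compound 4 is estimated at 6000 nM in this assay, within a range from 1500 nM to 30000 nM.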

Compound 4, half-maximal inhibitory concentration: 3000 nM
For compound 4 the middle estimate is 2.0-fold (0.30 log units) above the measured one, within the range that was stated.
By their numbers in this assay, from the lowest: compounds 4, 1 and 3 (each within the scatter of the next). At a limit, above all of these: compound 2.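

Placing 4-methylpiperazin-1-yl instead of trifluoromethyl on the aromatic carbon para to a large group gives a 1.1-fold lower number from compound 1 to compound 4 (0.06 log units; within the scatter) in this assay, so the two compounds cannot be told apart on this read-out. Among the compounds shown here, this position on the shared core therefore accepts a larger group containing a six-membered non-aromatic ring and hydrogen-bond acceptors, with no loss beyond the scatter, whereas the earlier compounds showed only trifluoromethyl here. Nothing among the data shown accounts for this result.

With just these two groups at this position, both giving numbers within the scatter of each other, no trend can be drawn. As far as these compounds go, how a carboxylic acid, a morpholine ring or a plain hydrogen at this position would read in this assay remains open.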